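Nitro to dimethyl on the benzamide: an expected loss

The source may hold more compounds than are shown below. What is called first, only, known or untested is meant among the compounds shown, and "the series" means these compounds.

Measured so far:
compound 1 `O=C(Nc1cc(-c2ccccc2)nn1-c1ccccc1)c1ccccc1` gives 203 nM
compound 2 `Cc1ccc(C(=O)Nc2cc(-c3ccccc3)nn2-c2ccccc2)cc1` gives 64 nM
compound 3 `O=C(Nc1cc(-c2ccccc2)nn1-c1ccccc1)c1ccc([N+](=O)[O-])cc1` gives 10.7 nM

Compound 3 holds the lowest number of the three in a functional assay on cells for positive allosteric modulation of metabotropic glutamate receptor 5 (Rattus norvegicus), read by calcium flux; on this read-out lower numbers stand for an effect already at smaller amounts and higher numbers for an effect only at larger amounts of compound; compound 2 lies a 6.0-fold lower number from compound 2 to compound 3 (0.78 log units; beyond the scatter) and compound 1 lies a 19-fold lower number from compound 1 to compound 3 (1.28 log units; beyond the scatter). Compound 4 `Cc1ccc(C(=O)Nc2cc(-c3ccccc3)nn2-c2ccccc2)cc1C` differs from compound 3 by 3,4-dimethylphenyl in place of 4-nitrophenyl on a carbonyl carbon. Among the measured compounds shown here, two measured steps bear on this: the change from methyl to nitro gave a 6.0-fold lower number from compound 2 to compound 3 (0.78 log units; beyond the scatter), and from hydrogen to methyl gave a 3.2-fold lower number from compound 1 to compound 2 (0.50 log units; beyond the scatter). For the measured compounds named here, a second methyl has no measured precedent here. Compound 4 is therefore expected to lose ground against compound 3, landing near compound 2: its estimated value is 40 nM, with a range of 15 nM to 130 nM. This estimate means a 3.7-fold higher number from compound 3 to compound 4 (0.57 log units; beyond the scatter), a step expected to lie beyond the scatter.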

Compound 4, half-maximal effective concentration: 20 nM
Compound 4: middle estimate off by 2.0-fold (0.30 log units), on the high side; the range from low to high includes it.
By their numbers in this assay, from the lowest: compounds 3 and 4 (each within the scatter of the next); then compound 2; then compound 1.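

Swapping 4-nitrophenyl for 3,4-dimethylphenyl on this carbonyl carbon gives a 1.9-fold higher number from compound 3 to compound 4 (0.27 log units; within the scatter), so here a ring of carbon only, with no hydrogen-bond acceptors, cannot be told apart from the nitro-bearing one. The added methyl gives a 3.2-fold lower number from compound 2 to compound 4 (0.51 log units; beyond the scatter), a step much like the earlier 3.2-fold lower number from compound 1 to compound 2 (0.50 log units; beyond the scatter), and the two methyls together give a 10-fold lower number from compound 1 to compound 4 (1.01 log units; beyond the scatter). Nothing measured here explains why these two different groups end up so close. From the compounds shown here alone, whether an amine, a carboxylic acid or a longer chain on this ring would hold up as well remains open.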